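This account rests on a few compounds, and the source may have more. Where it says the series, first, only, none or still open, it means among the compounds named here.

Measured in a functional assay on HL-60 cells (Homo sapiens) for cytotoxicity, read by MTT assay, with a stated time of 72 h; a higher number here means a weaker inhibitor, a lower number a stronger inhibitor:

- compound 1 `COC(=O)c1sc2ccccc2c1Nc1cc(OC)c(OC)c(OC)c1` gives 1540 nM
- compound 2 `COC(=O)c1sc2cccc(C)c2c1Nc1cc(OC)c(OC)c(OC)c1` gives 3390 nM

Compound 1 holds the lower of these two numbers. Among the compounds with values here, compound 3 `COC(=O)c1sc2ccc(C)cc2c1Nc1cc(OC)c(OC)c(OC)c1` is not yet measured and differs from compound 1 by methyl in place of hydrogen on an aromatic carbon as its only change. Within the data shown here, the one measured step of this kind, methyl in place of hydrogen on an aromatic carbon at a different place, is a 2.2-fold higher number from compound 1 to compound 2 (0.34 log units; beyond the scatter) and counts as modest. A modest rise in this assay is therefore expected, with a 1.6-fold higher number from compound 1 to compound 3 (0.19 log units; within the scatter) as the estimated step, although a single step is thin support. The expected value for compound 3 is 2400 nM within an estimated range of 1000 nM to 5500 nM.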

Compound 3, half-maximal inhibitory concentration: 4720 nM
Compound 3: middle estimate off by 2.0-fold (0.29 log units), on the low side, and the stated range covers the measured number.
By their numbers in this assay, from the lowest: compound 1; then compounds 2 and 3 (each within the scatter of the next).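

In this assay, methyl in place of hydrogen on an aromatic carbon, here meta to a fused ring and para to a fused ring, gives a 3.1-fold higher number from compound 1 to compound 3 (0.49 log units; beyond the scatter) and counts as modest. With a 2.2-fold higher number from compound 1 to compound 2 (0.34 log units; beyond the scatter) at the other place, the rise is now seen at two places on this ring, and compounds 2 and 3 lie within the scatter of each other. Nothing at hand accounts for the rise at either place.

Open, from the compounds shown here alone, is whether an amine, a carboxylic acid or a methoxy group at this position would also raise the number relative to compound 1. Also open, going by these compounds, is whether a longer chain such as ethyl would differ from methyl here.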